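From 4-Fluorophenyl to Cyclopropyl on a Carbonyl Carbon

The source may report more compounds than this note shows. Statements on the series, on what has been measured and on what is new or still open speak of the compounds shown alone.

In a functional assay on cells (Homo sapiens) for inhibition (a lower number here means a stronger inhibitor, a higher number a weaker inhibitor), compound 1 `O=C(/C=C\N(O)Cc1ccc(-c2ccccc2)cc1)c1ccc(F)cc1` gives 5200 nM. Compound 2 `O=C(/C=C\N(O)Cc1ccccc1)c1ccc(Cl)c(Cl)c1` gives 3600 nM, and the two numbers lie within the scatter of each other, so neither can be ranked over the other. Compound 3 `CC(=O)ON(/C=C\C(=O)c1ccc([N+](=O)[O-])cc1)Cc1ccccc1` is reported only as a limit of the assay, > 10000 nM.

The next compound to be tested is compound 4 `O=C(/C=C\N(O)Cc1ccc(-c2ccccc2)cc1)C1CC1`, which keeps the core of compound 1 and carries cyclopropyl in place of 4-fluorophenyl on a carbonyl carbon. Among the measured compounds shown here, no measured pair in this small set isolates a change at that carbonyl carbon, so the expectation remains loose. A small move toward a higher number in this assay is expected, meaning a somewhat weaker inhibitor, and a result within the scatter would not be surprising. The expected change is a 1.4-fold higher number from compound 1 to compound 4 (0.16 log units; within the scatter). For compound 4 the estimated value is 7500 nM, with an expected range of 2500 nM to 22000 nM.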

Compound 4, half-maximal inhibitory concentration: > 10000 nM
Compound 4 gave a limit, no number (the forecaster's own chance of this, stated with the estimate: 35%); middle value at least 1.3-fold (0.12 log units) away from the limit.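

Among the compounds shown here, replacing 4-fluorophenyl with cyclopropyl on a carbonyl carbon gives an at least 1.9-fold higher number from compound 1 to compound 4 (0.28 log units; that floor lies within the scatter) in this assay as the first reading of any change at this position. Since that step rests on a limit and not on a number, it shows that the change did not give a lower number, but its true size cannot be read and its floor alone does not separate compound 4 from compound 1. Compound 4 thus gives only a lower bound, and the assay's limit now holds a further compound of the set: the limit of > 10000 nM in this assay, at which 2 of the 4 values shown sit.

What the compounds shown leave open is whether a plain phenyl, a straight butyl chain or a dimethylamino group on that carbonyl carbon would give a value inside the measurable range. They also leave open how much of the reading of compound 1 depends on the fluorine itself.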